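Replacing Cyclohexyl with 4-Methoxyphenyl on the Ring Nitrogen

This account rests on a few compounds, and the source may have more. Where it says the series, first, only, none or still open, it means among the compounds named here.

Compounds measured in a functional assay on HCT-116 cells (Homo sapiens) for antiproliferative activity, read by MTT assay, with a stated time of 72 h; on this read-out lower numbers stand for stronger inhibition and higher numbers for weaker inhibition:
- compound 1 `COc1ncc(-c2ccc3c(c2)NC(=O)CO3)cc1NS(=O)(=O)c1ccc(F)cc1`: 24900 nM
- compound 2 `COc1cccc(N2C(=O)COc3ccc(-c4cnc(OC)c(NS(=O)(=O)c5ccc(F)cc5)c4)cc32)c1`: > 40000 nM (a limit)
- compound 3 `COc1ncc(-c2ccc3c(c2)N(C2CCCCC2)C(=O)CO3)cc1NS(=O)(=O)c1ccc(F)cc1`: > 40000 nM (a limit)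

Compound 3 has no numerical value in this assay, only the limit > 40000 nM. This is the same limit reached by compound 2, as the limit of > 40000 nM in this assay, at which 2 of the 3 values shown sit, shows.

Compound 4 `COc1ccc(N2C(=O)COc3ccc(-c4cnc(OC)c(NS(=O)(=O)c5ccc(F)cc5)c4)cc32)cc1` carries 4-methoxyphenyl in place of cyclohexyl on an amide-type nitrogen in a ring.

For the measured compounds named here, two measured steps bear on this change: an at least 1.6-fold higher number from compound 1 to compound 2 (0.20 log units; that floor lies within the scatter), and an at least 1.6-fold higher number from compound 1 to compound 3 (0.20 log units; that floor lies within the scatter). The direct comparison, a step that the two limits leave unreadable from compound 2 to compound 3, gives no size. Compound 2 is the nearest comparison, since it carries 3-methoxyphenyl at the same place. Resting on an at least 1.6-fold higher number from compound 1 to compound 2 (0.20 log units; that floor lies within the scatter), no step beyond the scatter is expected in this assay, and compound 4 is expected to remain close to the limit.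

The expected change is a number no higher from compound 3 to compound 4 (the limit leaves the size open).

For compound 4 the estimate is 40000 nM, with an expected range from 18000 nM to 80000 nM.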

Compound 4, half-maximal inhibitory concentration: 13400 nM
Beside the measured number, compound 4's estimate is 3.0-fold (0.47 log units) above it; the whole stated range lies above it.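

In this assay, the group on this amide-type nitrogen now separates the compounds, which the earlier limits could not show: 4-methoxyphenyl in place of cyclohexyl gives an at least 2.9-fold lower number from compound 3 to compound 4 (0.47 log units; beyond the scatter), and in place of 3-methoxyphenyl it gives an at least 2.9-fold lower number from compound 2 to compound 4 (0.47 log units; beyond the scatter). Against the amide hydrogen the step is a 1.9-fold lower number from compound 1 to compound 4 (0.27 log units; within the scatter), so a phenyl ring at this place need not cost anything measurable, provided it is 4-methoxyphenyl. The first two steps are floors rather than sizes: the limit of > 40000 nM in this assay, at which 2 of the 4 values shown sit.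

The compounds shown leave open how a 4-fluorophenyl, a 4-hydroxyphenyl or a simple methyl group on this nitrogen would read in this assay. They also leave open whether any group at this place can go beyond the scatter from compound 1.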